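This account rests on a few compounds, and the source may have more. Where it says the series, first, only, none or still open, it means among the compounds named here.

Measured compounds:
- compound 1 `CCOC(=O)c1cc(-c2ccc(Oc3ccccc3)cc2)nn1Cc1cccc(NC(=O)CCl)c1`, in a functional assay on JeKo-1 cells (Homo sapiens) for inhibition, read by luminescence and CellTiter-Glo, with a stated time of 72 h (on this read-out higher numbers stand for weaker inhibition and lower numbers for stronger inhibition), compound 1 gives 400 nM
- compound 2 `C=CC(=O)Nc1ccc(Cn2nc(-c3ccc(Oc4ccccc4)cc3)cc2C(=O)OCC)cc1`, compound 2 gives 10900 nM
- compound 3 `O=C(CCl)Nc1ccc(Cn2nc(-c3ccc(Oc4ccccc4)cc3)cc2C(=O)O)cc1`, compound 3 gives 2500 nM

Compound 3 stands second highest of the three numbers: its value lies beyond the scatter above compound 1 and beyond the scatter below compound 2.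

Compound 4 `CCOC(=O)c1cc(-c2ccc(Oc3ccccc3)cc2)nn1Cc1ccc(NC(=O)CCl)cc1` is not yet measured. It differs from compound 3 by ethyl in place of hydrogen on an oxygen next to a carbonyl group, that is, the carboxy group of compound 3 becomes an ethoxycarbonyl group.

For the measured compounds named here, none of the measured steps makes this change. Going by the values given here, the only step recorded, a 27-fold higher number from compound 1 to compound 2 (1.44 log units; beyond the scatter), alters a different part of the molecule, the group on the saturated chain carbon bound to an aromatic nitrogen, and leaves the ethyl ester untouched, so it says nothing direct about hydrogen to ethyl on that oxygen. What can be said is that both ester compounds, compound 1 and compound 2, carry the ethyl group already, and that their values bracket compound 3 on both sides.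

Among the compounds with values here, with no step on record for this change, the expectation for compound 4 is a modest move toward a lower number, a 2.5-fold lower number from compound 3 to compound 4 (0.40 log units; beyond the scatter), estimated at 1000 nM with a range from 250 nM to 4000 nM.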

Compound 4, half-maximal inhibitory concentration: 400 nM
For compound 4 the middle estimate is 2.5-fold (0.40 log units) above the measured one, and the stated range covers the measured number.
By their numbers in this assay, from the lowest: compounds 1 and 4 (each within the scatter of the next); then compound 3; then compound 2.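

In this assay, ethyl in place of hydrogen on the oxygen next to a carbonyl group now has a direct reading, a 6.3-fold lower number from compound 3 to compound 4 (0.80 log units; beyond the scatter), so for this pair the ethoxycarbonyl group goes with the lower number and the carboxy group with the higher one. Compound 4 also pulls apart the two differences that lay together in compounds 1 and 2: chloromethyl in place of vinyl on a carbonyl carbon gives a 27-fold lower number from compound 2 to compound 4 (1.44 log units; beyond the scatter), while 4-(((chloromethyl)carbonyl)amino)phenyl in place of 3-(((chloromethyl)carbonyl)amino)phenyl gives no change at the digits printed from compound 1 to compound 4 (within the scatter), so among these compounds the large gap follows the chloromethyl and vinyl change and not the placement of the amide on the phenyl ring. No measurement here accounts for any of these differences.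

The compounds shown leave open whether the ester result holds with vinyl in place of chloromethyl, since the carboxy group appears only with chloromethyl. They also leave open how a longer chain on that oxygen, such as propyl, or an amide in place of the ester, would compare with ethyl.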